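This account rests on a few compounds, and the source may have more. Where it says the series, first, only, none or still open, it means among the compounds named here.

Two compounds of the series carry numbers in an in vitro functional assay on SH-EP1 cells for agonist activity at Neuronal acetylcholine receptor; alpha4/beta2 (Homo sapiens), read by FLIPR and calcium flux; on this read-out higher numbers stand for an effect only at larger amounts of compound and lower numbers for an effect already at smaller amounts. Compound 1 `Clc1ccc(C2=CC3CNCC(C2)C3)nn1` gives 80 nM in this assay. Compound 2 `C1=C(c2cncc(Oc3ccccc3)c2)CC2CNCC1C2` gives 62 nM in this assay. The two numbers lie within the usual scatter of each other, so nothing separates compound 2 from compound 1 on these data, and compound 2 cannot be called stronger or weaker. Compound 3 `CC(C)Oc1cncc(C2=CC3CNCC(C2)C3)c1` has not been measured in this assay. It differs from compound 2 in one place: isopropyl in place of phenyl on an oxygen on an aromatic ring. Going by the values given here, no step between measured compounds touches this position, so the expectation rests on the run of the series alone. A shift near the scatter is expected, if any, leaning toward an effect only at somewhat larger amounts. The step of a 1.8-fold higher number from compound 2 to compound 3 (0.25 log units; within the scatter) is estimated to be modest. Compound 3 is expected to give 110 nM in this assay, with a range from 35 nM to 400 nM.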

Compound 3, half-maximal effective concentration: 164 nM
Compound 3: the middle estimate sits 1.5-fold (0.17 log units) below what was measured; measured number inside the range.
By their numbers in this assay, from the lowest: compounds 2 and 1 (each within the scatter of the next); then compound 3.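

In this assay, isopropyl in place of phenyl on an oxygen on an aromatic ring gives a 2.6-fold higher number from compound 2 to compound 3 (0.42 log units; beyond the scatter), the first step read at this position. The step lies beyond the scatter, so this position is not indifferent to the group on the oxygen: going from phenoxy to isopropoxy moves the effect to larger amounts of compound. Nothing at hand gives a reason for this shift.

A single pair cannot separate the loss of the aromatic ring from the change in the number of heavy atoms, since both come with the same step. Cyclohexyl on the same oxygen would keep a six-membered ring without aromaticity, and a longer straight chain such as n-butyl would have no ring at all, so either could help to tell these two apart.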